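Swapping the Aryl Group on the Ring Amine Nitrogen

The source may hold more compounds than are shown below. What is called first, only, known or untested is meant among the compounds shown, and "the series" means these compounds.

Of the compounds shown here, two have so far been tested in an assay on isolated protein for inhibition of protein kinase C zeta type (Homo sapiens), with a stated time of 4 min, tested at 62.5 uM; on this read-out lower numbers stand for less inhibition and higher numbers for more inhibition at the one concentration tested (going by the name of the read-out). Compound 1 `CC(C)(C)C1=NN(c2ccccc2Cl)C(c2ccc(O)cc2)C1` gives 57.1%. Compound 2 `CC(C)(C)C1=NN(c2c(Cl)cccc2Cl)C(c2ccc(O)cc2)C1`, which carries chloro in place of hydrogen on an aromatic carbon, gives 65.5%. Of the two numbers, the figure of compound 2 is the larger one, but the step of a number 8.4 percentage points higher from compound 1 to compound 2 (within the scatter) lies within the scatter of repeated measurements, so the two readings cannot truly be told apart. Compound 3 `CC(C)(C)C1=NN(c2ccc(F)c(Cl)c2)C(c2ccc(O)cc2)C1` has not yet been measured. It differs from compound 2 in one place: 3-chloro-4-fluorophenyl in place of 2,6-dichlorophenyl on an amine nitrogen in a ring. Among the measured compounds shown here, no measured step matches this kind of change; the only step available, a number 8.4 percentage points higher from compound 1 to compound 2 (within the scatter), concerns adding a single chloro and stayed within the scatter. Exchanging one arrangement of two halogens for another therefore gives no basis for expecting a step beyond the scatter in either direction, and the step from compound 2 is estimated at a number 7.5 percentage points lower from compound 2 to compound 3 (within the scatter). For compound 3 in this assay the value is expected to be 58%, with a likely range from 40% to 76%.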

Compound 3, a percentage reported as inhibition, at one concentration (the size of the read-out at that concentration, not a potency): 98.8%
The estimate for compound 3 lay 40.8 percentage points below the measured number; the whole stated range lies below it.
By their numbers in this assay, from the lowest: compounds 1 and 2 (each within the scatter of the next); then compound 3.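

The aryl group on this amine nitrogen in a ring clearly matters in this assay, which the single added chloro could not show: 3-chloro-4-fluorophenyl in place of 2,6-dichlorophenyl gives a number 33.3 percentage points higher from compound 2 to compound 3 (beyond the scatter), and in place of 2-chlorophenyl it gives a number 41.7 percentage points higher from compound 1 to compound 3 (beyond the scatter). Both steps lie beyond the scatter, and the groups in the first exchange match in heavy-atom count, hydrogen-bond donors and acceptors, and net charge, so those counts do not separate them; the difference lies in which halogens the phenyl ring carries and where they sit. Nothing measured here explains why this exchange gives so large a rise.

As far as these compounds go, the entering group differs from the other two in more than one respect, so it remains open whether a phenyl carrying only the chloro or only the fluoro would read like compound 3, and whether a methoxy group on the phenyl ring could stand in for either halogen. Each reading also comes from one concentration, so how the potencies of these compounds compare remains open as well.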